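The source may hold more compounds than are shown below. What is called first, only, known or untested is meant among the compounds shown, and "the series" means these compounds.

Measured so far in an ADME assay on MRC5 cells (Homo sapiens) for cytotoxicity, read by fluorescence and resazurin assay, with a stated time of 3 days; on this read-out higher numbers stand for weaker inhibition and lower numbers for stronger inhibition:
- Compound 1 (`Cc1ccc(Oc2cccc(CN3CCC(n4cc(C)c(=O)[nH]c4=O)CC3)c2)cc1`) gives > 64000 nM as a limit of the assay
- Compound 2 (`Cc1cn(C2CCN(Cc3cccc(Oc4ccc(Cl)c(Cl)c4)c3)CC2)c(=O)[nH]c1=O`) gives 6100 nM as a measured number

For the measured compounds named here, compound 2 holds the only actual number in this assay so far, with 6100 nM as its value. Compound 1 sits at the limit of > 64000 nM in this assay, at which 1 of the 2 values shown sits, and gives no number.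

Compound 3 (`Cc1cn(C2CCN(Cc3cccc(Oc4cccc(C(F)(F)F)c4)c3)CC2)c(=O)[nH]c1=O`) has not yet been measured. It departs from compound 2 at one place, and the change is 3-(trifluoromethyl)phenyl in place of 3,4-dichlorophenyl on an oxygen on an aromatic ring on an oxygen on an aromatic ring.

Going by the values given here, only one measured step bears on this place: an at least 10-fold lower number from compound 1 to compound 2 (1.02 log units; beyond the scatter) is large and beyond the scatter. It shows that the group on this oxygen can move the number considerably. Among the compounds with values here, that step, however, compares 4-methylphenyl with 3,4-dichlorophenyl, and no measured step compares 3,4-dichlorophenyl with 3-(trifluoromethyl)phenyl. No step beyond the scatter is therefore expected in this assay, with a slightly higher number the likelier direction. The expected step is a 1.5-fold higher number from compound 2 to compound 3 (0.17 log units; within the scatter) in this estimate. For compound 3 the estimated value is 9000 nM, with an expected range from 3500 nM to 25000 nM.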

Compound 3, half-maximal inhibitory concentration: 12400 nM
Compound 3: the middle estimate sits 1.4-fold (0.14 log units) below what was measured; the range from low to high includes it.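

The change to 3-(trifluoromethyl)phenyl gives a 2.0-fold higher number from compound 2 to compound 3 (0.31 log units; beyond the scatter) in this assay, a modest step which shows that the number still moves when one phenyl group bearing electron-poor-looking substituents is not at issue but simply when 3,4-dichlorophenyl is replaced on this oxygen.

Correction of that wording follows in plain terms: the position separates 3,4-dichlorophenyl from 3-(trifluoromethyl)phenyl, and not only from 4-methylphenyl. Replacing 4-methylphenyl with 3-(trifluoromethyl)phenyl gives an at least 5.1-fold lower number from compound 1 to compound 3 (0.71 log units; beyond the scatter), so among these three groups the order on this oxygen is set, with 3,4-dichlorophenyl giving the lowest number and 4-methylphenyl the highest. Compound 1 is a limit and not a number, and this step therefore has an open upper end: the limit of > 64000 nM in this assay, at which 1 of the 3 values shown sits.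

The compounds shown leave open how much of the change belongs to the chlorine or trifluoromethyl groups themselves, as an unsubstituted phenyl or a phenyl with a single chlorine does not appear among them. They also leave open how this number would respond to a nitrile, an amine or a carboxylic acid on the same phenyl ring.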